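Swapping the aryl on the triazole of a shared core

This account rests on a few compounds, and the source may have more. Where it says the series, first, only, none or still open, it means among the compounds named here.

Compound 1, `N#CC1=C(N)Oc2c(N)cc3nc4ccccc4nc3c2C12C(=O)N(Cc1cnnn1-c1ccc(Cl)cc1)c1ccccc12`, carries a 4-chlorophenyl on the triazole nitrogen of the shared core. In a functional assay on A549 cells (Homo sapiens) for antiproliferative activity, read by MTT assay, with a stated time of 48 h (on this read-out lower numbers stand for stronger inhibition and higher numbers for weaker inhibition), compound 1 returns only a limit, > 50000 nM. Compound 2, `CCOc1ccc(-n2nncc2CN2C(=O)C3(C(C#N)=C(N)Oc4c(N)cc5nc6ccccc6nc5c43)c3ccccc32)cc1`, differs by ethoxy in place of chloro on an aromatic carbon. In this assay compound 2 likewise returns only a limit, > 50000 nM. The step that the two limits leave unreadable from compound 1 to compound 2 therefore cannot be read, since both values sit at the same limit, as the limit of > 50000 nM in this assay, at which 2 of the 2 values shown sit, records. Compound 3, `Cc1ccc(C)c(-n2nncc2CN2C(=O)C3(C(C#N)=C(N)Oc4c(N)cc5nc6ccccc6nc5c43)c3ccccc32)c1`, is not yet measured; it differs from compound 2 by 2,5-dimethylphenyl in place of 4-ethoxyphenyl on an aromatic nitrogen. For the measured compounds named here, the only comparison available, the unreadable step from compound 1 to compound 2, gives no sign that changing the aryl on that nitrogen moves the read-out off the limit, so compound 3 is expected to stay there as well, an expected step that the limit leaves unreadable from compound 2 to compound 3. The estimate for compound 3 in this assay is 70000 nM, within 20000 nM to 250000 nM.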

Compound 3, half-maximal inhibitory concentration: > 50000 nM
Compound 3 was reported as a limit (the forecaster's own chance of this, stated with the estimate: 85%); the middle value does not contradict the limit.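

In this assay compound 3 returns > 50000 nM as a limit. Its steps from compound 1 and compound 2 therefore cannot be read: the limit of > 50000 nM in this assay, at which 3 of the 3 values shown sit. The three compounds leave open whether any aryl group on the triazole nitrogen of the shared core moves the read-out off this limit.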